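Swapping 4-bromophenyl for (4-chlorophenyl)amino on a carbonyl carbon

The compounds below may be only part of what the source reports. "The series", "measured", "known", "first", "only" and "open" are said of these compounds alone.

In a functional assay on OCI-Ly3 cells (Homo sapiens) for inhibition, read by CellTiter-Glo, with stated times of 48 h and 96 h (on this read-out lower numbers stand for stronger inhibition of growth and higher numbers for weaker inhibition of growth), compound 1 (`CC(C)[C@H](NC(=O)c1ccc(Br)cc1)C(=O)N1CCC[C@H]1C(=O)N[C@@H](CCCNC(=N)N)C(=O)CF`) gives 130 nM and is the strongest of the three measured compounds. Compound 3 (`CC(C)[C@H](NC(=O)C1CCCCC1)C(=O)N1CCC[C@H]1C(=O)N[C@@H](CCCNC(=N)N)C(=O)CF`) gives 940 nM and compound 2 (`CC(C)[C@H](NC(=O)c1ccc(C#N)cc1)C(=O)N1CCC[C@H]1C(=O)N[C@@H](CCCNC(=N)N)C(=O)CF`) gives 6660 nM on the same read-out. Among the compounds with values here, compound 4 (`CC(C)[C@H](NC(=O)Nc1ccc(Cl)cc1)C(=O)N1CCC[C@H]1C(=O)N[C@@H](CCCNC(=N)N)C(=O)CF`) has no measurement yet. It differs from compound 1 in one place: (4-chlorophenyl)amino in place of 4-bromophenyl on a carbonyl carbon in words, (4-chlorophenyl)amino in place of 4-bromophenyl on a carbonyl carbon.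

Within the data shown here, no measured step makes this exact change, so two related steps serve as a guide. Swapping bromo for cyano on the aromatic ring gave a large step (a 51-fold higher number from compound 1 to compound 2 (1.71 log units; beyond the scatter)). Replacing the 4-bromophenyl with cyclohexyl gave a modest one (a 7.2-fold higher number from compound 1 to compound 3 (0.86 log units; beyond the scatter)). Both raised the number, while compound 4 keeps an aromatic ring and a halogen. A modest step toward weaker inhibition is therefore expected (a 2.7-fold higher number from compound 1 to compound 4 (0.43 log units; beyond the scatter)). In this assay compound 4 is estimated at 350 nM with an expected range from 100 nM to 1500 nM at its two ends.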

Compound 4, concentration for 50% growth inhibition: 780 nM
Compound 4: the middle estimate sits 2.2-fold (0.35 log units) below what was measured; the range from low to high includes it.
By their numbers in this assay, from the lowest: compound 1; then compounds 4 and 3 (each within the scatter of the next); then compound 2.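

In this assay, (4-chlorophenyl)amino on the carbonyl carbon keeps an aromatic ring and a halogen, yet it still gives a clear loss against the 4-bromophenyl group (a 6.0-fold higher number from compound 1 to compound 4 (0.78 log units; beyond the scatter)), so these two features alone do not hold the level of compound 1. The new group sits within the scatter of cyclohexyl (a 1.2-fold lower number from compound 3 to compound 4 (0.08 log units; within the scatter)) and well clear of 4-cyanophenyl (an 8.5-fold lower number from compound 2 to compound 4 (0.93 log units; beyond the scatter)), which shows that a group with an aromatic ring can read the same as one without. No measurement here explains these differences.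

Compound 4 changes both the added nitrogen and the halogen, and the compounds shown leave open which of these accounts for the step. As far as these compounds go, a (4-bromophenyl)amino group would separate the two, and an amine or a carboxylic acid on the ring remains untested here.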